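The compounds below may be only part of what the source reports. "The series", "measured", "known", "first", "only" and "open" are said of these compounds alone.

The measured compounds are:
compound 1, `O=c1c(-c2nnc(-c3ccc(Cl)cc3)o2)c[nH]c2ncc(-c3cccnc3)cc12`, giving 20.1%;
compound 2, `CS(=O)(=O)c1ccc(-c2cnc3[nH]cc(-c4nnc(-c5cccnc5)o4)c(=O)c3c2)cc1`, giving 28.6%;
compound 3, `O=c1c(-c2nnc(-c3ccc(F)cc3)o2)c[nH]c2ncc(-c3ccncc3)cc12`, giving 19.6%.

All three values come from a functional assay on HCT-116 cells (Homo sapiens) for positive allosteric modulation, read by MTT assay, with stated times of 24 h and 48 h, tested at 2.5 uM; a higher number here means more inhibition of growth at the concentration tested, a lower number less inhibition of growth. Compound 2 shows the highest of the three numbers, but compound 1 and compound 3 both lie within the usual scatter of it, so no real order among the three can be claimed. Compound 4, `Cc1cccc(-c2nnc(-c3c[nH]c4ncc(-c5ccc(S(C)(=O)=O)cc5)cc4c3=O)o2)c1`, has not yet been measured. It differs from compound 2 in one place: 3-methylphenyl in place of pyridin-3-yl on an aromatic carbon. For the measured compounds named here, no measured pair here shows the effect of such a change, so the data give no guide to its size. The step from compound 2 to compound 4 is expected to be small, a number 4.6 percentage points lower from compound 2 to compound 4 (within the scatter), and not beyond the scatter. Compound 4 is therefore estimated at 24%, with a range from 12% to 36%.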

Compound 4, percent growth inhibition at one concentration: 50.8%
Estimate against measurement, compound 4: 26.8 percentage points below, outside the stated range (above it).
By their numbers in this assay, from the lowest: compounds 3, 1 and 2 (each within the scatter of the next); then compound 4.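

In this assay, for the compounds shown here, placing 3-methylphenyl instead of pyridin-3-yl on this aromatic carbon gives a number 22.2 percentage points higher from compound 2 to compound 4 (beyond the scatter), the only step here that can be read across a single change. The group at this position can therefore clearly shift growth inhibition at the tested concentration. Nothing available explains the rise.

As far as these compounds go, the change removes a ring nitrogen and adds a methyl together, so their separate shares remain unknown. A plain phenyl at this position would help separate them, while a 3-aminophenyl would test another group there.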